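Lengthening a butoxy chain into a pent-2-ynyloxy ether

A few compounds are considered here, and "the series" means these few. Any claim that something is new, unique, unknown or untested is made for them only; others in the source may bear on it.

Measured compounds in an assay on cells with melanin-concentrating hormone receptor 1 (Homo sapiens) as the target, read by radioligand binding; a lower number here means a stronger inhibitor, a higher number a weaker inhibitor:
- compound 1, `CCC(C)COc1cccc2ccc(N)nc12`: 36 nM
- compound 2, `CC#CCCOc1cccc2ccc(N)nc12`: > 2000 nM, a limit of the assay and not a number
- compound 3, `CCCCOc1cccc2ccc(N)nc12`: 789 nM

Compound 3 stands highest of the two numbers, with compound 1 as its nearest neighbour at a lower value: a 22-fold higher number from compound 1 to compound 3 (1.34 log units; beyond the scatter). For compound 2 the value sits at the limit of > 2000 nM in this assay, at which 1 of the 3 values shown sits, which is a limit of the assay and not a number.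

Compound 4, `CCC#CCOc1cccc2ccc(N)nc12`, differs from compound 3 by but-1-yn-1-yl in place of propyl on a saturated chain carbon bound to an oxygen on an aromatic ring. Within the data shown here, two measured steps bear on this change. The step of an at least 2.5-fold lower number from compound 2 to compound 3 (0.40 log units; beyond the scatter) shows that removing the triple bond from the chain lowers the number, so introducing one should raise it. The step of an at least 55-fold higher number from compound 1 to compound 2 (1.74 log units; beyond the scatter) shows that exchanging a branched sec-butyl for a but-2-yn-1-yl chain raises the number strongly. Compound 4 keeps a linear chain and adds a triple bond, so the number is expected to rise beyond the scatter, with a fair chance that only a limit is reported.

Compound 4 is therefore estimated at 2500 nM, within a range from 800 nM to 8000 nM, which corresponds to an expected step of a 3.2-fold higher number from compound 3 to compound 4 (0.50 log units; beyond the scatter).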

Compound 4, half-maximal inhibitory concentration: > 2000 nM
Compound 4: no number, only a limit (the forecaster's own chance of this, stated with the estimate: 50%); the middle value lies beyond the limit too.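

In this assay, the butyl to pent-2-yn-1-yl change gives an at least 2.5-fold higher number from compound 3 to compound 4 (0.40 log units; beyond the scatter), so the drop in strength seen with the triple bond of compound 2 now recurs in a second chain carrying one. Against the branched sec-butyl chain, the change gives an at least 55-fold higher number from compound 1 to compound 4 (1.74 log units; beyond the scatter), which again sets the branched ether well apart from the chains with a triple bond. Compound 4 gives > 2000 nM, which is a limit of the assay and not a number, so the step to compound 2 cannot be read and the two chains with a triple bond cannot be ranked: the limit of > 2000 nM in this assay, at which 2 of the 4 values shown sit.

Going by these compounds, how far past that limit these two compounds lie stays open, and with it whether the place of the triple bond within the chain matters at all. Also open, on these data alone, is whether a double bond in place of the triple bond would behave like the butyl chain or like the pent-2-yn-1-yl chain, and whether a cyclopropylmethyl ether would match the sec-butyl chain of compound 1.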